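Dichlorocinnamate esters and amides: ring-chlorine removal

The source may hold more compounds than are shown below. What is called first, only, known or untested is meant among the compounds shown, and "the series" means these compounds.

Measured compounds in a functional assay on the whole organism for inhibition, with Brassica rapa subsp. chinensis as the target, with a stated time of 3 days, tested at 100 ppm; a lower number here means less inhibition of growth, a higher number more inhibition of growth at the concentration tested:
compound 1 `Cc1ccc(OC(=O)/C=C/c2ccc(Cl)cc2Cl)c(C(C)C)c1`, 32%;
compound 2 `O=C(/C=C/c1ccccc1)NCc1ccc(Cl)cc1Cl`, 0%;
compound 3 `Cc1ccc(OC(=O)/C=C/c2ccc(Cl)cc2)c(C(C)C)c1`, 41%.

Compound 2 stands lowest of the three; the difference between its core and the core of compound 1 is not broken down here. Between compound 1 and compound 3 the change is hydrogen in place of chloro on an aromatic carbon, and the step is a number 9 percentage points higher from compound 1 to compound 3 (within the scatter). Compound 4 `O=C(/C=C/c1ccccc1)NCc1ccc(Cl)cc1` is not yet measured; it differs from compound 2 by hydrogen in place of chloro on an aromatic carbon, the same change at the same kind of place.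

Within the data shown here, for compound 4 in this assay a step of about a number 5 percentage points higher from compound 2 to compound 4 (within the scatter) is expected, because the one measured instance of this change gave a number 9 percentage points higher from compound 1 to compound 3 (within the scatter) and compound 2 itself gave 0%. Compound 4 is therefore estimated at 5%, likely between 0% and 20%.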

Compound 4, percent growth inhibition at one concentration: 6%
Compound 4: the middle estimate sits 1 percentage points below what was measured; low and high end bracket the measured number.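

In this assay, hydrogen in place of chloro on an aromatic carbon gives a number 6 percentage points higher from compound 2 to compound 4 (within the scatter), so the step also stays within the scatter on this second core. Set beside the earlier step, the change reads alike on both cores: the same change on two cores in this assay, a number 9 percentage points higher (within the scatter) from compound 1 to compound 3 and a number 6 percentage points higher (within the scatter) from compound 2 to compound 4, 3 percentage points apart, within the scatter of two such steps. Among these compounds, neither step can be told from the scatter, so the agreement shows only that the change gave no readable step on either core, and it does not show that the chloro plays any part in growth inhibition or that the result would hold on a further core.

Still open, on these data alone, is whether fluoro, methoxy or trifluoromethyl in place of this chloro would give a step beyond the scatter. Also open, as far as these compounds go, is how a longer chain between the amide nitrogen and the ring would read.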